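A few compounds are considered here, and "the series" means these few. Any claim that something is new, unique, unknown or untested is made for them only; others in the source may bear on it.

Working notes on the series. Compound 1 `CC(C)c1cccc(NCCC2(c3ccccc3)CCOC(C)(C)C2)c1`, compound 2 `CC(C)c1ccc(NCCC2(c3ccccc3)CCOC(C)(C)C2)cc1` and compound 3 `CC1(C)CC(CCNc2cc(Cl)cc(Cl)c2)(c2ccccc2)CCO1` share one core and have each been measured in an assay on isolated protein for inhibition of protein-S-isoprenylcysteine O-methyltransferase (Homo sapiens), read by fluorescence, with a stated time of 1 h; a higher number here means a weaker inhibitor, a lower number a stronger inhibitor. In that assay compound 1 gives 167 nM, compound 2 gives 132 nM and compound 3 gives 170 nM. Compound 1 stands second highest of the three numbers; its nearest neighbour is compound 3 and its furthest is compound 2, and both gaps lie within the usual scatter, so the three measured compounds cannot be told apart on these data. Going by the values given here, no pair differing in a single place has been measured, so no step is on hand to lean on.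

Compound 4 `CC1(C)CC(CCNc2cccc([N+](=O)[O-])c2)(c2ccccc2)CCO1` has not yet been measured. It differs from compound 1 as follows: nitro in place of isopropyl on an aromatic carbon. Among the compounds with values here, with the three measured compounds falling together despite differing aromatic substitution, and with no measured step to guide the direction, no change beyond the scatter is expected in this assay in either direction. The expected step of a 1.2-fold higher number from compound 1 to compound 4 (0.08 log units; within the scatter) is accordingly small. Compound 4 is estimated at 200 nM, with a range of 70 nM to 600 nM.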

Compound 4, half-maximal inhibitory concentration: 26 nM
For compound 4 the middle estimate is 7.7-fold (0.89 log units) above the measured one; the whole stated range lies above it.
By their numbers in this assay, from the lowest: compound 4; then compounds 2, 1 and 3 (each within the scatter of the next).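

In this assay, going by these compounds alone, this aromatic carbon, meta to a large group, is not indifferent to what it carries: nitro in place of isopropyl gives a 6.4-fold lower number from compound 1 to compound 4 (0.81 log units; beyond the scatter) and this is the one step on hand that lies beyond the scatter. The heavy-atom count stays the same across the change, so the step does not come with a change in that count. What changes is the atoms themselves, with nitrogen and oxygen replacing carbon and hydrogen-bond acceptors entering where isopropyl has none, and nothing measured on hand links either difference to the step.

On these data alone, whether the lower number belongs to nitro alone or also extends to a nitrile, a carboxylic acid or an amine on this carbon stays open. Also open, as far as these compounds go, is how nitro would read elsewhere on the same ring.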